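This account rests on a few compounds, and the source may have more. Where it says the series, first, only, none or still open, it means among the compounds named here.

In an ADME assay on the whole organism (strain CD-1) for metabolic stability, with Mus musculus as the target, at a dose of 50 mg/kg by the oral route (a lower number here means that the compound disappears faster, a higher number that the compound lasts longer), compound 3 `O=C(NC[C@@H]1CC(Br)=NO1)[C@@H]1C[C@@H](O)CN1C(=O)OCc1cnc2ccccc2c1` gives 0.25 h, level with compound 1 `O=C(NC[C@@H]1CC(Br)=NO1)[C@@H]1C[C@@H](c2ccc(O)cc2)CN1C(=O)OCc1cnc2ccccc2c1` at 0.25 h and compound 2 `O=C(NC[C@@H]1CC(Br)=NO1)[C@@H]1C[C@@H](OCc2ccccc2)CN1C(=O)OCc1cnc2ccccc2c1` at 0.25 h. Compound 4 `O=C(NC[C@@H]1CC(Br)=NO1)[C@@H]1C[C@@H](c2ccccc2)CN1C(=O)OCc1cnc2ccccc2c1` is still unmeasured and differs from compound 3 by a single change: phenyl in place of hydroxy on a saturated ring carbon. Two measured changes on that carbon bear on this: no change at the digits printed from compound 1 to compound 3 (within the scatter), with hydroxy in place of 4-hydroxyphenyl, and no change at the digits printed from compound 1 to compound 2 (within the scatter), with benzyloxy in place of 4-hydroxyphenyl. Neither step goes beyond the scatter, so no real shift in half-life is expected here. The expected step is no change at the digits printed from compound 3 to compound 4 (within the scatter). The estimate for compound 4 is 0.25 h, with an expected range from 0.15 h to 0.5 h.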

Compound 4, half-life: 0.25 h
The estimate for compound 4 equals the measured number at the digits printed; the range from low to high includes it.
By their numbers in this assay, from the lowest: compounds 1, 2, 3 and 4 (each within the scatter of the next).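

In this assay a plain phenyl on this saturated ring carbon gives no change at the digits printed from compound 3 to compound 4 (within the scatter) and no change at the digits printed from compound 2 to compound 4 (within the scatter) and also no change at the digits printed from compound 1 to compound 4 (within the scatter) when the hydroxy leaves the aromatic ring. Phenyl, which has no hydrogen-bond donor or acceptor, therefore stands level with hydroxy, benzyloxy and 4-hydroxyphenyl at this position. No supporting measurement is available to explain this flat result. On these data alone, whether an amine, a carboxylic acid or a longer chain on this carbon would shift the half-life remains open. So does whether a change elsewhere in the shared core would.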